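The compounds below may be only part of what the source reports. "The series", "measured", "known", "first", "only" and "open" are said of these compounds alone.

Measured in a functional assay on MCF7 cells (Homo sapiens) for antiproliferative activity, read by MTT assay, with a stated time of 72 h; on this read-out lower numbers stand for stronger inhibition and higher numbers for weaker inhibition:
- compound 1 `O=C(N/N=C/c1ccccc1)Nc1ccc(Oc2ccnc3[nH]ccc23)c(F)c1` gives 2380 nM
- compound 2 `O=C(N/N=C/c1ccc(F)cc1)Nc1ccc(Oc2ccnc3[nH]ccc23)c(F)c1` gives 800 nM
- compound 3 `O=C(N/N=C/c1ccc(O)cc1)Nc1ccc(Oc2ccnc3[nH]ccc23)c(F)c1` gives "not active" (no number reported)

Compound 1 has the higher of the two numbers, and compound 3 has no number. The next structure, compound 4 `O=C(N/N=C/c1ccccc1)Nc1ccc(Oc2ccnc3[nH]ccc23)cc1`, is not yet measured. It differs from compound 1 by hydrogen in place of fluoro on an aromatic carbon. For the measured compounds named here, the only measured exchange of this type is a 3.0-fold lower number from compound 1 to compound 2 (0.47 log units; beyond the scatter). That modest step added fluoro at a different place, so it is only a loose guide. A small rise in the number is expected in this assay, possibly none beyond the scatter. The expected change is a 1.3-fold higher number from compound 1 to compound 4 (0.10 log units; within the scatter). For compound 4 the estimate is 3000 nM, with an expected range of 1000 nM to 9000 nM.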

Compound 4, half-maximal inhibitory concentration: 1510 nM
Compound 4: middle estimate off by 2.0-fold (0.30 log units), on the high side; measured number inside the range.
By their numbers in this assay, from the lowest: compounds 2, 4 and 1 (each within the scatter of the next, the first and the last beyond it).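

In this assay, hydrogen in place of the fluoro that sits ortho to a large group and meta to a large group gives a 1.6-fold lower number from compound 1 to compound 4 (0.20 log units; within the scatter) and stays within the scatter, so this fluoro is not required for the antiproliferative read-out in this pair. The other fluoro exchange, a 3.0-fold lower number from compound 1 to compound 2 (0.47 log units; beyond the scatter), lies beyond the scatter, so the two places do not respond alike. No data here explain this difference. Going by these compounds, whether chloro, methoxy or an amine at this place would shift the number remains open. Also open, on these data alone, is whether the fluoro of compound 2 keeps its step when this fluoro is replaced by hydrogen.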